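Second chloro on the benzyl arm of compound 2

The source may hold more compounds than are shown below. What is called first, only, known or untested is meant among the compounds shown, and "the series" means these compounds.

Of the compounds shown here, three on a shared core have been measured so far. Compound 1 `O=C(NC(=S)Nc1ccccc1)Nc1ccc2c(c1)C(=O)C(=O)N2Cc1ccccc1` gives 2.48 in a physicochemical assay for lipophilicity, in phosphate buffer, measured as octanol-water partition; a higher number here means a more lipophilic compound, a lower number a more polar compound. Compound 2 `O=C(NC(=S)Nc1ccccc1Cl)Nc1ccc2c(c1)C(=O)C(=O)N2Cc1ccccc1` gives 3.01, and compound 3 `Cc1ccc(NC(=S)NC(=O)Nc2ccc3c(c2)C(=O)C(=O)N3Cc2ccccc2)cc1` gives 2.96. Among these, a number 0.53 log units higher from compound 1 to compound 2 (beyond the scatter) is beyond the scatter, whereas a number 0.05 log units lower from compound 2 to compound 3 (within the scatter) is within it, so compound 2 stands beyond compound 1 and level with compound 3. Compound 4 `O=C(NC(=S)Nc1ccccc1Cl)Nc1ccc2c(c1)C(=O)C(=O)N2Cc1ccccc1Cl` carries the change (chloro in place of hydrogen on an aromatic carbon). Going by the values given here, the steps that bear on it are a number 0.53 log units higher from compound 1 to compound 2 (beyond the scatter) and a number 0.48 log units higher from compound 1 to compound 3 (beyond the scatter), each a single substituent entering an outer phenyl ring, each modest and upward. A step of that size is expected again, a number 0.49 log units higher from compound 2 to compound 4 (beyond the scatter). Compound 4 is accordingly estimated at 3.5, with a range from 3.1 to 3.9.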

Compound 4, partition coefficient: 3.98
Compound 4: middle estimate off by 0.48 log units, on the low side; the whole stated range lies below it.
By their numbers in this assay, from the lowest: compound 1; then compounds 3 and 2 (each within the scatter of the next); then compound 4.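

Chloro entering the benzyl arm, benzyl to 2-chlorobenzyl, gives in this assay a number 0.97 log units higher from compound 2 to compound 4 (beyond the scatter) and this is a larger step than a number 0.53 log units higher from compound 1 to compound 2 (beyond the scatter) for phenyl to 2-chlorophenyl. In this pair of steps, the second chloro adds more than the first, so the series shows no constant increment per chloro. Nothing measured here accounts for the size of the step.

Going by these compounds, it remains open whether the step belongs to the benzyl arm itself or depends on the chloro on the phenyl arm: 2-chlorobenzyl appears here only alongside 2-chlorophenyl. On these data alone, how a methyl, an amine or a carboxylic acid in the same place compares also remains open.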